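The source may hold more compounds than are shown below. What is called first, only, known or untested is meant among the compounds shown, and "the series" means these compounds.

Of the compounds shown here, three built on one shared core have been tested in an assay on isolated protein for inhibition of 2-Hydroxyacid oxidase 2 (Homo sapiens), tested at 10 uM; on this read-out lower numbers stand for a weaker effect and higher numbers for a stronger effect at the one concentration tested. Compound 1 `Cc1n[nH]c(C(=O)O)c1Cc1cccc(C(=O)O)c1` gives 0%, compound 2 `Cc1n[nH]c(C(=O)O)c1Cc1ccc(C(F)(F)F)cc1` gives 12%, and compound 3 `Cc1n[nH]c(C(=O)O)c1Cc1cccc(C#N)c1` gives 19%. Compound 2 thus stands second highest of the three: compound 3 is its nearest neighbour, within the scatter, and compound 1 its furthest, beyond it. Among the measured compounds shown here, the only measured step, a number 19 percentage points higher from compound 1 to compound 3 (beyond the scatter), exchanges one group on the aromatic ring for another. Compound 4 `Cc1n[nH]c(C(=O)O)c1Cc1ccc(C(N)=O)cc1` differs from compound 2 by carbamoyl in place of trifluoromethyl on an aromatic carbon. Carbamoyl itself has not been measured, and the one step only shows that such exchanges on this ring shift this assay modestly. A small downward step is therefore expected, a number 4 percentage points lower from compound 2 to compound 4 (within the scatter). Compound 4 is estimated at 8%, between 0% and 25%.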

Compound 4, a percentage reported as inhibition, at one concentration (the size of the read-out at that concentration, not a potency): 8%
Compound 4: middle estimate and measured number agree at the digits printed; low and high end bracket the measured number.
By their numbers in this assay, from the lowest: compounds 1, 4, 2 and 3 (each within the scatter of the next, the first and the last beyond it).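

At this position, on an aromatic carbon para to a large group, trifluoromethyl has no hydrogen-bond donor or acceptor, while carbamoyl has one of each. In this assay, among the compounds shown here, that exchange gives a number 4 percentage points lower from compound 2 to compound 4 (within the scatter), so the two groups cannot be told apart here, and adding a donor and an acceptor at this position produces no measurable step. No available data explain this result. From the compounds shown here alone, it remains open how an amine or a longer chain at this position would read in this assay. A single tested concentration also leaves the potency of these compounds unknown.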